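This account rests on a few compounds, and the source may have more. Where it says the series, first, only, none or still open, it means among the compounds named here.

Measured so far in a functional assay on L1210 cells (Mus musculus) for inhibition, read by cell counting, with a stated time of 2 days; a lower number here means a stronger inhibitor, a higher number a weaker inhibitor:
compound 1 `C=C(Br)C(=O)Nc1cccc(-c2cn3nc(-c4ccc(OC)c(OC)c4)sc3n2)c1` gives 42 nM;
compound 2 `C=C(Br)C(=O)Nc1cccc(-c2cn3nc(-c4ccc(OCC)cc4)sc3n2)c1` gives 790 nM;
compound 3 `C=C(Br)C(=O)Nc1cccc(-c2cn3nc(-c4ccc(Cl)cc4)sc3n2)c1` gives 1400 nM.

Among these three, compound 3 has the highest number. Its nearest neighbour is compound 2, and that gap, a 1.8-fold higher number from compound 2 to compound 3 (0.25 log units; within the scatter), lies within the scatter, so the two cannot be ranked. The gap to compound 1, a 33-fold higher number from compound 1 to compound 3 (1.52 log units; beyond the scatter), is large, as is the related step of a 19-fold higher number from compound 1 to compound 2 (1.27 log units; beyond the scatter).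

Compound 4 `C=C(Br)C(=O)Nc1cccc(-c2cn3nc(Cc4ccc(Cl)cc4)sc3n2)c1` is the next step from compound 3. The change is 4-chlorobenzyl in place of 4-chlorophenyl on an aromatic carbon. The three measured steps all swap one substituent pattern on the outer ring for another while the ring stays directly attached to the shared core; none of them inserts a carbon between the ring and the core. So no measured step bears directly on this change, and its direction cannot be read from the data in hand. The best anchor is simply where compound 3 stands, with a wide allowance either way.

Compound 4 is therefore expected to give about 2000 nM in this assay, somewhere between 400 nM and 10000 nM. That expectation amounts to a step of a 1.4-fold higher number from compound 3 to compound 4 (0.15 log units; within the scatter), which is within the scatter of compound 3.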

Compound 4, half-maximal inhibitory concentration: 2300 nM
For compound 4 the middle estimate is 1.2-fold (0.06 log units) below the measured one; low and high end bracket the measured number.
By their numbers in this assay, from the lowest: compound 1; then compounds 2, 3 and 4 (each within the scatter of the next, the first and the last beyond it).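

In this assay, going by these compounds alone, the outer ring had so far always been attached directly to the shared core. With 4-chlorobenzyl in place of 4-chlorophenyl, a 1.6-fold higher number from compound 3 to compound 4 (0.22 log units; within the scatter) lies within the scatter, so at this position the added carbon leaves no readable difference when the ring carries chlorine. The comparisons with the other compounds show that this change does not close the distance to the best compound shown: a 2.9-fold higher number from compound 2 to compound 4 (0.46 log units; beyond the scatter) is modest but beyond the scatter, whereas a 55-fold higher number from compound 1 to compound 4 (1.74 log units; beyond the scatter) is large and leaves the 3,4-dimethoxyphenyl group of compound 1 well apart from the 4-chlorobenzyl group. No measurement offered here explains how the added carbon or these ring substituents act on the cells.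

The compounds shown leave open whether a 3,4-dimethoxybenzyl group, which pairs the added carbon with the two methoxy groups, would stay close to compound 1 or fall away from it as a group. They also leave open how a longer chain such as phenylethyl, or an outer ring carrying an amine or a carboxylic acid, would fare at this same position.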